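Triazole-linked chromone ethers: a para-methoxybenzyl variant

The source may hold more compounds than are shown below. What is called first, only, known or untested is meant among the compounds shown, and "the series" means these compounds.

Compounds measured so far:
Compound 1, `O=c1ccoc2cc(OCc3cn(Cc4ccc(Cl)cc4)nn3)ccc12`: 41700 nM
Compound 2, `O=c1ccoc2cc(OCc3cn(Cc4ccccc4F)nn3)ccc12`: 36900 nM

In a functional assay on QGY7701 cells (Homo sapiens) for cytotoxicity, read by MTT assay, with a stated time of 48 h (on this read-out lower numbers stand for stronger inhibition and higher numbers for weaker inhibition), compound 1 gives 41700 nM and compound 2 gives 36900 nM. Going by the values given here, the only step between measured compounds, a 1.1-fold lower number from compound 1 to compound 2 (0.05 log units; within the scatter), leaves the two within the scatter of each other, so compound 2 stands at one of two numbers that cannot be told apart on this assay.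

Compound 3, `COc1ccc(Cn2cc(COc3ccc4c(=O)ccoc4c3)nn2)cc1`, has not yet been measured. Its difference from compound 2 is 4-methoxyphenyl in place of 2-fluorophenyl on a saturated chain carbon bound to an aromatic nitrogen. This is a change of the same kind as the one already seen: a substituted phenyl exchanged for another substituted phenyl at the same place, on a saturated chain carbon bound to an aromatic nitrogen. Among the compounds with values here, the one step that bears on it, a 1.1-fold lower number from compound 1 to compound 2 (0.05 log units; within the scatter), was within the scatter. No measured step therefore gives a reason to expect a move beyond the scatter in this assay for compound 3.

Compound 3 is accordingly expected to give about 38000 nM, with a range of 15000 nM to 95000 nM, which amounts to an estimated step of a 1.0-fold higher number from compound 2 to compound 3 (0.01 log units; within the scatter).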

Compound 3, half-maximal inhibitory concentration: 56600 nM
The estimate for compound 3 lay 1.5-fold (0.17 log units) below the measured number; low and high end bracket the measured number.
By their numbers in this assay, from the lowest: compounds 2, 1 and 3 (each within the scatter of the next).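

In this assay, the step of a 1.5-fold higher number from compound 2 to compound 3 (0.19 log units; within the scatter) and the step of a 1.4-fold higher number from compound 1 to compound 3 (0.13 log units; within the scatter) both stay inside the usual scatter, so all three compounds remain within the scatter of one another. The earlier pair had only exchanged one halogen-bearing phenyl for another, whereas 4-methoxyphenyl brings in oxygen and a hydrogen-bond acceptor by the count for that group, and even so the number does not separate from those of compound 1 and compound 2. At this place on a saturated chain carbon bound to an aromatic nitrogen, these three substituted phenyl groups therefore cannot be told apart in this assay, and nothing available explains why their numbers sit together.

The compounds shown leave open whether an amine or a carboxylic acid on this phenyl ring, or a longer chain in place of the benzyl carbon, would give a step beyond the scatter. They also leave open what the substituent and its ring position each contribute, as 2-fluorophenyl and 4-methoxyphenyl differ in both at once.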